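A Larger Side Chain on the Shared Core

The source may hold more compounds than are shown below. What is called first, only, known or untested is meant among the compounds shown, and "the series" means these compounds.

Of the compounds shown here, two built on the same shared core have been tested in a functional assay on A549 cells (Homo sapiens) for inhibition, read by MTT assay, with a stated time of 24 h; a higher number here means a weaker inhibitor, a lower number a stronger inhibitor. Compound 1, `CCOC(=O)C1=Cc2ccccc2OC1(OCc1cc(-c2ccc(C)cc2)no1)C(F)(F)F`, gives only a limit there, > 150000 nM. Compound 2, `CCOC(=O)C1=Cc2ccccc2OC1(OCc1cn(-c2ccccc2)nn1)C(F)(F)F`, likewise gives no number in this assay, only the limit > 150000 nM. Compound 2 thus stands where compound 1 stands, at the edge of the measurement, as the limit of > 150000 nM in this assay, at which 2 of the 2 values shown sit, records. Compound 3, `CCOC(=O)C1=Cc2ccccc2OC1(OCc1cn(CC(=O)Nc2cccc(F)c2)nn1)C(F)(F)F`, differs from compound 2 in one place: ((3-fluorophenyl)carbamoyl)methyl in place of phenyl on an aromatic nitrogen, in words ((3-fluorophenyl)carbamoyl)methyl in place of phenyl on an aromatic nitrogen. Among the compounds with values here, no step between measured compounds exists in this set, so nothing measured tells how far such a change moves the result. With both measured compounds sitting at the limit, the step from compound 2 to compound 3 in this assay is expected to be no change beyond the scatter, which is what a step that the limit leaves unreadable from compound 2 to compound 3 expresses. Compound 3 is therefore estimated at about 200000 nM, within a range from 60000 nM to 600000 nM, and most likely it will again be reported only as a limit.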

Compound 3, half-maximal inhibitory concentration: > 150000 nM
Compound 3 gave a limit, no number (the forecaster's own chance of this, stated with the estimate: 75%); the middle value is on the limit's open side.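

In this assay compound 3 gives > 150000 nM, which is a limit and not a number. Within the data shown here, compound 2 also gives only a limit there, so no step from compound 2 to compound 3 can be read. All the compounds shown stand at one place: the limit of > 150000 nM in this assay, at which 3 of the 3 values shown sit.

The compounds shown leave open which side chain on the shared core, if any, would give a measurable value.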